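The source may hold more compounds than are shown below. What is called first, only, known or untested is meant among the compounds shown, and "the series" means these compounds.

Measured so far:
- compound 1 `CCOC(=O)[C@@H]1CCC[C@@H](S(=O)(=O)c2ccc(S(=O)(=O)N(CC)CC)cc2)C1`: 5000 nM
- compound 2 `CC(C)c1noc(N2CCN(C(=O)[C@@H]3CCCN(S(=O)(=O)c4ccc(S(=O)(=O)NC(C)(C)C)cc4)C3)CC2)n1`: 100 nM
- compound 3 `CC(C)c1noc(N2CCN(C(=O)[C@@H]3CCCN(S(=O)(=O)c4ccc(S(=O)(=O)C(C)C)cc4)C3)CC2)n1`: 30 nM

In a functional assay on MIA PaCa-2 cells (Homo sapiens) for inhibition, read by MTT assay, with a stated time of 3 days (a lower number here means a stronger inhibitor, a higher number a weaker inhibitor), compound 3 holds the lowest of the three numbers; compound 2 is nearest and compound 1 furthest, both gaps beyond the scatter. Compound 4 `CC(C)c1noc(N2CCN(C(=O)[C@@H]3CCCN(S(=O)(=O)c4ccc(S(=O)(=O)NC5CCC5)cc4)C3)CC2)n1` differs from compound 3 by cyclobutylamino in place of isopropyl on a sulfonyl sulfur. Among the measured compounds shown here, one measured step bears on this: a 3.3-fold lower number from compound 2 to compound 3 (0.52 log units; beyond the scatter), where (tert-butyl)amino on the sulfonyl sulfur gave way to isopropyl. For the measured compounds named here, compound 4 runs that change backwards, restoring a sulfamoyl group, now carrying cyclobutylamino rather than (tert-butyl)amino; no measured pair covers that second difference. The expected outcome is therefore a modest rise, a 2.7-fold higher number from compound 3 to compound 4 (0.43 log units; beyond the scatter), beyond the scatter. Compound 4 is estimated at 80 nM, with a range of 30 nM to 250 nM.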

Compound 4, half-maximal inhibitory concentration: 200 nM
The estimate for compound 4 lay 2.5-fold (0.40 log units) below the measured number; the range from low to high includes it.
By their numbers in this assay, from the lowest: compound 3; then compounds 2 and 4 (each within the scatter of the next); then compound 1.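

In this assay, isopropyl on the sulfonyl sulfur now holds its lower number against a second sulfonamide, not only the (tert-butyl)amino one (a 6.7-fold higher number from compound 3 to compound 4 (0.82 log units; beyond the scatter)). The substituent on the sulfonamide nitrogen shows no separation so far, with cyclobutyl and tert-butyl not told apart (a 2.0-fold higher number from compound 2 to compound 4 (0.30 log units; within the scatter)). Nothing available explains why the isopropyl compound 3 stands apart from these two sulfonamides.

Open, as far as these compounds go, is how dimethylamino on the same sulfonyl sulfur would compare within the core of compound 3. Also open, from the compounds shown here alone, is whether a cyclopropyl group or a longer chain such as n-butyl there would match isopropyl.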